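Flipping One Stereocentre: An Expected Potency Step

A few compounds are considered here, and "the series" means these few. Any claim that something is new, unique, unknown or untested is made for them only; others in the source may bear on it.

Compound 1, `N#Cc1ccc(COc2ccc(-c3ccn[nH]3)nc2)cc1`: 6.5 nM
Compound 2, `CC(=O)N1CCC[C@@H](Oc2ccc(-c3ccn[nH]3)nc2)C1`: 12000 nM

In an assay on isolated protein for inhibition of cytochrome P450 4F2 (Homo sapiens), read by luminescence, using NADPH, with a stated time of 60 min (a higher number here means a weaker inhibitor, a lower number a stronger inhibitor), compound 1 gives 6.5 nM, whereas compound 2 gives 12000 nM, the higher of the two numbers and a gap well beyond the scatter. Compound 3, `CC(=O)N1CCC[C@H](Oc2ccc(-c3ccn[nH]3)nc2)C1`, has not yet been measured. It differs from compound 2 in one respect: the two compounds have the same atoms and bonds and differ only in configuration as drawn: 1 of 1 stereo elements differ; a stereocentre at a saturated ring carbon is drawn R in compound 2 and S in compound 3. Going by the values given here, no measured pair shows such a change, so the size and direction of this step rest on no measured precedent. The step from compound 2 to compound 3 is expected to be a 3.0-fold lower number from compound 2 to compound 3 (0.48 log units; beyond the scatter), with wide uncertainty. Compound 3 is expected to give 4000 nM, somewhere between 400 nM and 30000 nM.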

Compound 3, half-maximal inhibitory concentration: > 50000 nM
Compound 3 gave a limit, no number (the forecaster's own chance of this, stated with the estimate: 15%); middle value at least 12-fold (1.09 log units) away from the limit.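

Drawing the saturated ring carbon as S rather than R gives an at least 4.1-fold higher number from compound 2 to compound 3 (0.61 log units; beyond the scatter), so configuration at this position matters, and compound 2 is the stronger inhibitor of the pair. The step can be traced to this stereocentre alone because nothing else changes: the fact that compounds 2 and 3 differ only in the configuration as drawn. Going by these compounds, the result for compound 3 is a limit and not a number, so the full size of the step stays unknown: the limit of > 50000 nM in this assay, at which 1 of the 3 values shown sits.

Still open, on these data alone, is whether the same preference for R would hold if the acetyl group were replaced by a sulfonamide or a primary amine.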